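A hydroxy added to the aromatic ring of compound 2

The compounds below may be only part of what the source reports. "The series", "measured", "known", "first", "only" and "open" are said of these compounds alone.

In a functional assay on HeLa cells (Homo sapiens) for antiproliferative activity, read by MTT assay, with a stated time of 48 h (a lower number here means a stronger inhibitor, a higher number a weaker inhibitor), compound 1 (`C=C(c1cc(OC)c(OC)c(OC)c1)c1ccc(OC)cc1NC(=O)CO`) gives 30 nM and compound 2 (`C=C(c1cc(OC)c(OC)c(OC)c1)c1ccc(OC)cc1NC(=O)CN(C)C`) gives 370 nM, the higher of the two numbers, which makes compound 2 the weaker inhibitor of the pair. For the measured compounds named here, its nearest neighbour is therefore compound 1, and the gap between them is the only measured step: a 12-fold higher number from compound 1 to compound 2 (1.09 log units; beyond the scatter), with dimethylamino in place of hydroxy on a saturated chain carbon bound to a carbonyl carbon.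

Compound 3 (`C=C(c1cc(OC)c(OC)c(OC)c1)c1ccc(OC)c(O)c1NC(=O)CN(C)C`) keeps the side chain of compound 2 and changes elsewhere: hydroxy in place of hydrogen on an aromatic carbon. Going by the values given here, no measured step touches this place on the ring, so the step above bears on it only loosely. It shows that one change on this core can move the number well beyond the scatter, and compound 1 shows that the core can reach 30 nM. The expected change is a 2.5-fold lower number from compound 2 to compound 3 (0.39 log units; beyond the scatter), a modest move toward a lower number, although the data do not settle the direction. For compound 3 the estimated value in this assay is 150 nM, with an expected range of 30 nM to 600 nM.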

Compound 3, half-maximal inhibitory concentration: 120 nM
Compound 3: middle estimate off by 1.3-fold (0.10 log units), on the high side, and the stated range covers the measured number.
By their numbers in this assay, from the lowest: compound 1; then compound 3; then compound 2.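

In this assay, for the compounds shown here, the step of a 3.1-fold lower number from compound 2 to compound 3 (0.49 log units; beyond the scatter) gives the first reading of this aromatic carbon, which lies ortho to a (((dimethylamino)methyl)carbonyl)amino group and ortho to a methoxy group. The earlier step changed only the side chain, whereas this one shows that the ring itself can also move the number: with the dimethylamino side chain kept, replacing hydrogen with hydroxy at this carbon makes the compound a stronger inhibitor, not a weaker one. Nothing available here explains this shift.

As far as these compounds go, this single step rests on the dimethylamino side chain alone, so it remains open whether the same hydroxy would also lower the number on the hydroxy side chain of compound 1, where the value is already 30 nM. From the compounds shown here alone, it also remains open whether the effect is specific to hydroxy, since a methoxy, an amine or a fluorine on this same aromatic carbon could give a different number, and one hydroxy at one place says nothing about the other open carbons of this ring.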